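Amide replacements on the shared core: compound 4

The source may hold more compounds than are shown below. What is called first, only, known or untested is meant among the compounds shown, and "the series" means these compounds.

Among the measured compounds shown here, compound 1 `Nc1sc(-c2ccc(Cl)cc2)c(-c2ccc(Cl)cc2)c1C(=O)NCc1ccccc1` gives 16300 nM in a functional assay on A549 cells (Homo sapiens) for inhibition, read by sulforhodamine B assay, with a stated time of 72 h (a lower number here means a stronger inhibitor, a higher number a weaker inhibitor), the highest number among the three measured members. Compound 2 `Nc1sc(-c2ccc(Cl)cc2)c(-c2ccc(Cl)cc2)c1C(=O)NC1CC1` gives 1950 nM, and compound 3 `Nc1sc(-c2ccc(Cl)cc2)c(-c2ccc(Cl)cc2)c1C(=O)N1CCCCC1=O` gives 1820 nM. Both steps away from the benzylamino of compound 1 lowered the number: an 8.4-fold lower number from compound 1 to compound 2 (0.92 log units; beyond the scatter) and a 9.0-fold lower number from compound 1 to compound 3 (0.95 log units; beyond the scatter); between those two, a 1.1-fold lower number from compound 2 to compound 3 (0.03 log units; within the scatter). Compound 4 `CC1CN(C(=O)c2c(N)sc(-c3ccc(Cl)cc3)c2-c2ccc(Cl)cc2)CCN1` carries the change (3-methylpiperazin-1-yl in place of benzylamino on a carbonyl carbon). The two measured steps, each a replacement of the same benzylamino on the carbonyl carbon, bear directly on it, and compound 3 with its 2-oxopiperidin-1-yl is the closer analogue. A step of similar size and the same direction is therefore expected, an 8.2-fold lower number from compound 1 to compound 4 (0.91 log units; beyond the scatter). Compound 4 is estimated at 2000 nM, within 700 nM to 6000 nM.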

Compound 4, half-maximal inhibitory concentration: 4930 nM
The estimate for compound 4 lay 2.5-fold (0.39 log units) below the measured number, and the stated range covers the measured number.
By their numbers in this assay, from the lowest: compounds 3 and 2 (each within the scatter of the next); then compound 4; then compound 1.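

Replacing benzylamino on a carbonyl carbon with 3-methylpiperazin-1-yl still lowers the number (a 3.3-fold lower number from compound 1 to compound 4 (0.52 log units; beyond the scatter)), so this gain is not confined to the two earlier replacements. The gain is smaller, however, as compound 4 sits above both earlier replacements (a 2.7-fold higher number from compound 3 to compound 4 (0.43 log units; beyond the scatter); a 2.5-fold higher number from compound 2 to compound 4 (0.40 log units; beyond the scatter)). The position therefore separates these replacements of benzylamino rather than giving one common level.

On these data alone, whether piperazin-1-yl without the methyl, or morpholine, would fall with compound 4 or with compound 2 and compound 3 remains open. No available evidence bears on why these steps differ.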